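Methyl Added to a Bisphenol Heterocycle

The source may report more compounds than this note shows. Statements on the series, on what has been measured and on what is new or still open speak of the compounds shown alone.

Measured so far:
compound 1 `COc1ccc(-c2cc(-c3ccc([N+](=O)[O-])cc3)on2)cc1` — its value in an ADME assay (Mus musculus) for antiproliferative activity, read by cell counting, with a stated time of 5 days (a lower number here means a stronger inhibitor, a higher number a weaker inhibitor), is a limit, > 100000 nM
compound 2 `Oc1ccc(-c2cc(-c3ccc(O)cc3)on2)cc1` — in this assay compound 2 gives 2500 nM

Compound 1 carries a methoxy group and a nitro group, and in this assay it reaches only the limit, (the limit of > 100000 nM in this assay, at which 1 of the 2 values shown sits). Among the measured compounds shown here, compound 2 carries two hydroxyls instead and is the only compound with a measured number; the one further value shown is a limit, so there is no measured step against which compound 2 can be placed.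

Compound 3 `Cc1c(-c2ccc(O)cc2)noc1-c1ccc(O)cc1` differs from compound 2 by methyl in place of hydrogen on an aromatic carbon. For the measured compounds named here, no step between measured compounds is available to guide the size of this change. The account expects no movement beyond the usual scatter in this assay for so small an addition. Compound 3 is therefore estimated at 2500 nM, with a range from 800 nM to 8000 nM, and the step of no change at the digits printed from compound 2 to compound 3 (within the scatter) is expected to stay within scatter.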

Compound 3, half-maximal inhibitory concentration: 19000 nM
Estimate against measurement, compound 3: 7.6-fold (0.88 log units) below; the measured number lies above the stated range.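

Compound 3 shows that the aromatic carbon of the five-membered ring, two ring bonds from both the ring nitrogen and the ring oxygen, is not indifferent to substitution in this assay: methyl in place of hydrogen gives a 7.6-fold higher number from compound 2 to compound 3 (0.88 log units; beyond the scatter). This is the only measured step shown, and it shows that methyl alone can move the number this far while both hydroxyls stay in place. Nothing measured here accounts for the size of this step.

The compounds shown leave open whether the higher number is particular to methyl or would also follow another group at this carbon, such as an ethyl chain, a chlorine atom or an amine. From the compounds shown here alone, it also remains open whether methyl would have a similar effect if either hydroxyl were replaced.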